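Halogen for alkyl on the pendant phenyl: compound 4

The compounds below may be only part of what the source reports. "The series", "measured", "known", "first", "only" and "open" are said of these compounds alone.

Compound 1 `CCc1ccc(-n2nc(-c3ccc(C(F)(F)F)cc3O)nc2-c2ccccc2O)cc1`: 64.4%
Compound 2 `CC(C)c1ccc(-n2nc(-c3ccc(C(F)(F)F)cc3O)nc2-c2ccccc2O)cc1`: 69.7%
Compound 3 `Oc1cc(C(F)(F)F)ccc1-c1nc(-c2ccccc2O)n(-c2ccc(Cl)cc2)n1`: 68%

All three numbers come from a functional assay on PC-12 cells (Rattus norvegicus) for cytotoxicity, read by MTT assay, with stated times of 2 h and 24 h, tested at 1 uM; on this read-out lower numbers stand for a weaker effect and higher numbers for a stronger effect at the one concentration tested. Compound 2 holds the largest number of the three, but the gaps to the other two are both within the scatter: a number 1.7 percentage points lower from compound 2 to compound 3 (within the scatter) and a number 5.3 percentage points higher from compound 1 to compound 2 (within the scatter). On these numbers the three compounds are indistinguishable.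

Compound 4 `Oc1cc(C(F)(F)F)ccc1-c1nc(-c2ccccc2O)n(-c2ccc(I)cc2)n1` differs from compound 2 at the same place as compound 3 does: iodo in place of isopropyl on an aromatic carbon. Among the measured compounds shown here, the steps that bear on it are those in which a halogen replaced an alkyl group on that aromatic carbon. Both were small: a number 1.7 percentage points lower from compound 2 to compound 3 (within the scatter) and a number 3.6 percentage points higher from compound 1 to compound 3 (within the scatter), each within the scatter. A second halogen in place of the same isopropyl group is therefore expected to give no step beyond the scatter, a number 1.7 percentage points lower from compound 2 to compound 4 (within the scatter), in no particular direction. Compound 4 is accordingly estimated at 68%, with a range from 58% to 78%.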

Compound 4, a percentage reported as activity, at one concentration (the size of the read-out at that concentration, not a potency): 70.1%
Compound 4: the middle estimate sits 2.1 percentage points below what was measured; low and high end bracket the measured number.
By their numbers in this assay, from the lowest: compounds 1, 3, 2 and 4 (each within the scatter of the next).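

In this assay, iodo in place of isopropyl gives a number 0.4 percentage points higher from compound 2 to compound 4 (within the scatter), iodo in place of chloro gives a number 2.1 percentage points higher from compound 3 to compound 4 (within the scatter), and iodo in place of ethyl gives a number 5.7 percentage points higher from compound 1 to compound 4 (within the scatter). With a second halogen now at this aromatic carbon, neither the choice of halogen nor the choice between halogen and alkyl separates the four compounds shown. No measurement shown explains this flat picture.

Going by these compounds, whether an amine, a carboxylic acid or a methoxy group at this position would give a step beyond the scatter remains open. Also open, on these data alone, is whether the four compounds would still stand level at other concentrations, since a reading at a single concentration gives no potency.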